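This account rests on a few compounds, and the source may have more. Where it says the series, first, only, none or still open, it means among the compounds named here.

The measured compounds in a functional assay on NPC-TW01 cells (Homo sapiens) for antiproliferative activity, read by MTT assay, with a stated time of 72 h; on this read-out lower numbers stand for stronger inhibition of growth and higher numbers for weaker inhibition of growth:
Compound 1, `O=C(COc1c(-c2ccccc2)oc2ccccc2c1=O)Nc1ccccc1`, gives only a limit of the assay, > 10000 nM.
Compound 2, `COc1ccc(NC(=O)COc2c(-c3ccccc3)oc3ccccc3c2=O)cc1`, gives 5480 nM.
Compound 3, `O=C(COc1ccc2oc(-c3ccccc3)cc(=O)c2c1)Nc1ccc(F)cc1`, gives 740 nM.

Compound 3 stands lowest of the two numbers, with compound 2 as its nearest neighbour; one further value is a limit. The unmeasured compound 4, `O=C(COc1ccc2oc(-c3ccccc3)cc(=O)c2c1)Nc1ccc(-c2ccccc2)cc1`, differs from compound 3 by phenyl in place of fluoro on an aromatic carbon. Among the measured compounds shown here, the only measured single-point step is an at least 1.8-fold lower number from compound 1 to compound 2 (0.26 log units; that floor lies within the scatter), a change on an aromatic carbon of a different core with a different group, and it stays within the scatter, so it bears only loosely here. For the measured compounds named here, no step of the same kind is known, so the range is kept wide. Compound 4 is expected to give 1500 nM, between 400 nM and 6000 nM, which means an expected step of a 2.0-fold higher number from compound 3 to compound 4 (0.31 log units; beyond the scatter).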

Compound 4, concentration for 50% growth inhibition: 640 nM
Beside the measured number, compound 4's estimate is 2.3-fold (0.37 log units) above it; low and high end bracket the measured number.
By their numbers in this assay, from the lowest: compounds 4 and 3 (each within the scatter of the next); then compound 2. At a limit, above all of these: compound 1.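

In this assay, phenyl in place of fluoro on an aromatic carbon, para to a large group, gives a 1.2-fold lower number from compound 3 to compound 4 (0.06 log units; within the scatter). Among the compounds shown here, this position therefore accepts the far larger phenyl with no difference beyond the scatter, which the earlier compounds could not show. Nothing measured here accounts for this result. Going by these compounds, whether an amine, a carboxylic acid or a longer chain at this position would read the same remains open. So does whether phenyl would behave alike on the core of compound 2.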